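A few compounds are considered here, and "the series" means these few. Any claim that something is new, unique, unknown or untested is made for them only; others in the source may bear on it.

Measured so far:

Compound 1, `COc1cc(-c2cc(/C=C/C(=O)c3ccc(N)cc3)[nH]n2)cc(OC)c1OC`, 4330 nM in a functional assay on A498 cells (Homo sapiens) for inhibition, read by sulforhodamine B assay, with a stated time of 48 h; on this read-out lower numbers stand for stronger inhibition of growth and higher numbers for weaker inhibition of growth.
Compound 2, `COc1ccc(-c2cc(/C=C/C(=O)c3ccc(N)cc3)[nH]n2)cc1OC`, 7090 nM in this assay.
Compound 3, `COc1cc(C(=O)/C=C/c2cc(-c3cc(OC)c(OC)c(OC)c3)n[nH]2)cc(OC)c1OC`, 3590 nM in this assay.

The three numbers sit within the usual scatter of one another, so no order among them is claimed. Compound 3 gives the lowest of the three numbers, with compound 1 nearest and compound 2 furthest, both within the scatter.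

One step is measured: a 1.6-fold higher number from compound 1 to compound 2 (0.21 log units; within the scatter). The change is hydrogen in place of methoxy on an aromatic carbon.

Compound 4, `COc1ccc(-c2cc(/C=C/C(=O)c3cc(OC)c(OC)c(OC)c3)[nH]n2)cc1OC`, awaits measurement in this assay. It differs from compound 3 by hydrogen in place of methoxy on an aromatic carbon. This is the same change as from compound 1 to compound 2; the surroundings of the place are described in the same words in both cases. The difference between the core of compound 1 and the core of compound 3 is not broken down here.

For compound 4 the expected step is a 1.5-fold higher number from compound 3 to compound 4 (0.19 log units; within the scatter), resting on the measured step of a 1.6-fold higher number from compound 1 to compound 2 (0.21 log units; within the scatter), which lay within the scatter. Compound 4 is therefore estimated at 5500 nM, with a range from 2500 nM to 12000 nM.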

Compound 4, concentration for total growth inhibition: 4990 nM
Estimate against measurement, compound 4: 1.1-fold (0.04 log units) above; the measured number falls inside the stated range.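

In this assay, hydrogen in place of methoxy on an aromatic carbon gives a 1.4-fold higher number from compound 3 to compound 4 (0.14 log units; within the scatter). Set beside the earlier case, the change reads alike on the two cores: the same change on two cores in this assay, a 1.6-fold higher number (0.21 log units; within the scatter) from compound 1 to compound 2 and a 1.4-fold higher number (0.14 log units; within the scatter) from compound 3 to compound 4, 1.2-fold (0.07 log units) apart, within the scatter of two such steps. Within this pair of cores, the change therefore carries over as a small step, but neither step stands clear of the scatter, so no real effect of removing the methoxy group is shown, and two cores give no rule for other cores in the series.

Open is how a hydroxy group, an amine or a carboxylic acid in place of that methoxy group would read in this assay, since only methoxy and hydrogen are shown there. Also open, going by these compounds, is whether a step beyond the scatter appears when a longer chain such as ethoxy or propoxy stands at that place, or when the remaining methoxy groups on the same ring are replaced as well.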